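Sulfonyl aryl change from the lowest compound

The source may hold more compounds than are shown below. What is called first, only, known or untested is meant among the compounds shown, and "the series" means these compounds.

- compound 1 `N#Cc1ccc(O[C@H]2CN(S(=O)(=O)c3ccc(Cl)cc3Cl)C[C@@]2(O)CO)cc1F` gives 54 L/kg
- compound 2 `N#Cc1ccc(O[C@H]2CN(S(=O)(=O)c3ccc(Cl)cc3Cl)C[C@@]2(O)CN)cc1F` gives 210 L/kg
- compound 3 `N#Cc1ccc(O[C@H]2CN(S(=O)(=O)c3ccc(Cl)cc3Cl)C[C@]2(O)CO)cc1F` gives 330 L/kg

In an ADME assay on the whole organism (Rattus norvegicus, strain Sprague-Dawley) for pharmacokinetics, read by LC-MS, with a stated time of 30 min (on this read-out lower numbers stand for narrower distribution and higher numbers for wider distribution into tissues), compound 1 stands lowest of the three. Compound 4 `N#Cc1ccc(O[C@H]2CN(S(=O)(=O)c3ccc(Cl)cn3)C[C@@]2(O)CO)cc1F` has 5-chloropyridin-2-yl in place of 2,4-dichlorophenyl on a sulfonyl sulfur. Neither measured step touches that place. The amino for hydroxy change gives a 3.9-fold higher number from compound 1 to compound 2 (0.59 log units; beyond the scatter) and the change of configuration (the fact that compounds 1 and 3 differ only in the configuration as drawn) gives a 6.1-fold higher number from compound 1 to compound 3 (0.79 log units; beyond the scatter) as modest steps beyond the scatter. Both show how far single changes moved this number, but neither gives a direction for the new change. No step beyond the scatter is therefore firmly expected, and the estimate stays close to compound 1 (54 L/kg). The expected step is a 1.4-fold lower number from compound 1 to compound 4 (0.13 log units; within the scatter) with wide uncertainty. The estimate for compound 4 is 40 L/kg (expected range 13 L/kg to 130 L/kg).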

Compound 4, volume of distribution at steady state: 12 L/kg
Estimate against measurement, compound 4: 3.3-fold (0.52 log units) above, outside the stated range (below it).
By their numbers in this assay, from the lowest: compound 4; then compound 1; then compounds 2 and 3 (each within the scatter of the next).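

Among these compounds, on the sulfonyl sulfur, a place no earlier step touched, 5-chloropyridin-2-yl in place of 2,4-dichlorophenyl gives a 4.5-fold lower number from compound 1 to compound 4 (0.65 log units; beyond the scatter) in this assay. Among the compounds shown here, this is the first step from compound 1 that lowers the number, so the sulfonyl aryl group moves this read-out downward, whereas the amino and configuration steps both raise it. Nothing shown here gives a reason for this step.

The change swaps a ring carbon for nitrogen and removes a chlorine together, so a plain pyridin-2-yl or 4-chlorophenyl group would be needed to separate the two. Going by these compounds, whether 5-chloropyridin-2-yl gives a similar step on compound 2 or compound 3 also remains open.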